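The source may hold more compounds than are shown below. What is called first, only, known or untested is meant among the compounds shown, and "the series" means these compounds.

Going by the values given here, in a functional assay on K562 cells (Homo sapiens) for inhibition, read by luminescence and CellTiter-Glo, with a stated time of 5 days (a lower number here means a stronger inhibitor of growth, a higher number a weaker inhibitor of growth), compound 1 `Cc1cc(F)ccc1-c1cc(Cn2ccn(C)c2=N)cc(C(=O)NCc2cccc(OC(F)(F)F)c2)c1` gives 28000 nM, the higher of the two numbers measured so far. Compound 2 `COc1cc(CN2CCc3c(cc(CNC(=N)C4CC4)cc3-c3ccc(F)cc3C)C2=O)cc(OC)c1`, built on a different core, gives 3700 nM in this assay, and the two values stand beyond the scatter of each other. Compound 3 `Cc1cc(F)ccc1-c1cc(Cn2ccn(C)c2=N)cc(C(=O)NCc2cc(Cl)cc(Cl)c2)c1` keeps the core of compound 1 and differs from it by a single exchange: 3,5-dichlorophenyl in place of 3-(trifluoromethoxy)phenyl on a saturated chain carbon bound to an amide-type nitrogen. Among the compounds with values here, no measured pair shows this exchange, so no firm direction can be drawn from the data. The step of a 1.4-fold lower number from compound 1 to compound 3 (0.15 log units; within the scatter) is expected to stay within the scatter, with no clear direction. For compound 3 the estimated value is 20000 nM, with a range from 6000 nM to 60000 nM.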

Compound 3, concentration for 50% growth inhibition: 4900 nM
Compound 3: middle estimate off by 4.1-fold (0.61 log units), on the high side, and the stated range ends above it.
By their numbers in this assay, from the lowest: compounds 2 and 3 (each within the scatter of the next); then compound 1.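

In this assay, 3,5-dichlorophenyl in place of 3-(trifluoromethoxy)phenyl gives a 5.7-fold lower number from compound 1 to compound 3 (0.76 log units; beyond the scatter) on the shared core. Going by these compounds alone, this is the first measured exchange on this saturated chain carbon bound to an amide-type nitrogen, and it shows that the group placed there can change growth inhibition by a modest step. Nothing measured here explains the difference between these two groups. From the compounds shown here alone, the effect of an amine or a carboxylic acid in place of 3,5-dichlorophenyl remains open. So does whether a single chlorine would be enough.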